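The source may report more compounds than this note shows. Statements on the series, on what has been measured and on what is new or still open speak of the compounds shown alone.

Measured so far in an assay on SH-EP1 cells for agonist activity at Neuronal acetylcholine receptor; alpha4/beta2 (Homo sapiens), read by FLIPR and calcium flux; a lower number here means a smaller maximal response, a higher number a larger maximal response:
Compound 1 `CCCC(=O)N1CC2CC(C1)N2`: 120%
Compound 2 `O=C(C1CC=CC1)N1CC2CC(C1)N2`: 93%

Compound 1 stands highest of these two numbers; compound 2 sits lower by a gap beyond the usual scatter. Compound 3 `O=C([C@@H]1C[C@H]1F)N1CC2CC(C1)N2` differs from compound 1 in one place: 2-fluorocyclopropyl in place of propyl on a carbonyl carbon. Among the compounds with values here, no step between two measured compounds is available to guide this change, so the expectation rests on compound 2, which also carries a ring on the carbonyl carbon and gives 93%. A decrease of moderate size in this assay is expected, likely reaching beyond the scatter. The expected step is a number 25 percentage points lower from compound 1 to compound 3 (beyond the scatter). For compound 3 the estimate is 95%, within a range from 70% to 125%.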

Compound 3, largest response reached (Emax), in percent of the reference or control that the assay uses: 110%
Compound 3: the middle estimate sits 15 percentage points below what was measured, and the stated range covers the measured number.
By their numbers in this assay, from the lowest: compound 2; then compounds 3 and 1 (each within the scatter of the next).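

In this assay, putting 2-fluorocyclopropyl in place of propyl on the carbonyl carbon gives a number 10 percentage points lower from compound 1 to compound 3 (within the scatter), so compound 1 and compound 3 cannot be told apart. A ring on this carbonyl carbon therefore does not always lower the maximal response, even though compound 2 reads lower than compound 1 by a gap beyond the scatter. Nothing available explains this result.

On these data alone, how plain cyclopropyl, without the fluorine, or a longer chain such as pentyl would behave on this carbonyl carbon remains open. Also open, as far as these compounds go, is whether the mirror-image form of 2-fluorocyclopropyl would give a similar response.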